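The source may hold more compounds than are shown below. What is called first, only, known or untested is meant among the compounds shown, and "the series" means these compounds.

Measured compounds:
compound 1 `Cc1cn(C2CCN(Cc3cccc(Oc4cccc(Cl)c4)c3)CC2)c(=O)[nH]c1=O` — 21000 nM
compound 2 `Cc1cn(C2CCN(Cc3cccc(Oc4ccc(O)cc4)n3)CC2)c(=O)[nH]c1=O` — "not determined" (no result reported)
compound 3 `Cc1cn(C2CCN(Cc3ccnc(Oc4cccc(Cl)c4)c3)CC2)c(=O)[nH]c1=O` — > 64000 nM

In an ADME assay on MRC5 cells (Homo sapiens) for cytotoxicity, read by fluorescence and resazurin assay, with a stated time of 3 days (on this read-out lower numbers stand for stronger inhibition and higher numbers for weaker inhibition), compound 1 gives 21000 nM, the only single number among the three compounds shown. Compound 2 carries no result in this assay, "not determined" (no result reported). Compound 3 reaches only a limit of the assay, (the limit of > 64000 nM in this assay, at which 1 of the 3 values shown sits). For the measured compounds named here, no pair of measured compounds differs in just one place, so no measured step is available to guide the next one.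

Compound 4 `COc1cccc(Oc2cccc(CN3CCC(n4cc(C)c(=O)[nH]c4=O)CC3)c2)c1` differs from compound 1 by methoxy in place of chloro on an aromatic carbon. Going by the values given here, with no measured step to rest on, the expected step of a 1.4-fold higher number from compound 1 to compound 4 (0.15 log units; within the scatter) is small, toward weaker inhibition, and hardly beyond the usual scatter. Compound 4 is therefore estimated at 30000 nM, in a range from 12000 nM to 64000 nM.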

Compound 4, half-maximal inhibitory concentration: 25300 nM
Compound 4: middle estimate off by 1.2-fold (0.07 log units), on the high side; the measured number falls inside the stated range.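

In this assay, for the compounds shown here, methoxy in place of chloro on an aromatic carbon, meta to a large group, gives a 1.2-fold higher number from compound 1 to compound 4 (0.08 log units; within the scatter) and so provides the first measured step at this position. At this position, the 3-chlorophenoxy and 3-methoxyphenoxy groups are not told apart by this read-out, even though methoxy brings one hydrogen-bond acceptor that chloro lacks. Nothing measured here accounts for this step. The compounds shown leave open whether an amine or a carboxylic acid at this position would shift the number beyond the scatter.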